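The source may hold more compounds than are shown below. What is called first, only, known or untested is meant among the compounds shown, and "the series" means these compounds.

Measured in an ADME assay on HCT-116 cells (Homo sapiens) for cytotoxicity, read by CellTiter-Glo, with a stated time of 72 h; on this read-out lower numbers stand for stronger inhibition and higher numbers for weaker inhibition:

- Compound 1 `CC1CCN(C2CCN(S(=O)(=O)c3cccc4ccccc34)CC2)CC1`: > 10000 nM
- Compound 2 `CC1CCN(C2CCN(S(=O)(=O)c3cccnc3)CC2)CC1`: > 10000 nM

Compound 2 stands at > 10000 nM, which is a limit of the assay and not a number. Compound 1 gives > 10000 nM, which is also a limit. Neither compound has a measured potency, so the two cannot be ranked against each other.

The next compound is compound 3 `Cc1ccc(S(=O)(=O)N2CCC(N3CCC(C)CC3)CC2)cc1C`, which keeps the rest of compound 2 and carries 3,4-dimethylphenyl in place of pyridin-3-yl on a sulfonyl sulfur. Going by the values given here, no measured step between two compounds is available as a guide. The expectation in this assay is therefore no step beyond the usual scatter, because the limit of > 10000 nM in this assay, at which 2 of the 2 values shown sit, is all that compound 1 and compound 2 show. Compound 3 may well return only a limit too. Should it give a number, compound 3 is expected at 12000 nM, within an estimated range of 5000 nM to 30000 nM. The estimated change is a step that the limit leaves unreadable from compound 2 to compound 3.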

Compound 3, half-maximal inhibitory concentration: > 5000 nM
Compound 3: no number, only a limit (the forecaster's own chance of this, stated with the estimate: 80%); the middle value does not contradict the limit.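

In this assay compound 3 gives > 5000 nM as a limit of the assay and not a number. Going by these compounds alone, compound 2 gives > 10000 nM as a limit too, so no step from compound 2 to compound 3 can be read. The compounds shown leave open how strongly any of them acts in this assay and whether 3,4-dimethylphenyl in place of pyridin-3-yl on a sulfonyl sulfur makes any difference.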